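The compounds below may be only part of what the source reports. "The series", "measured", "known", "first", "only" and "open" are said of these compounds alone.

Measured so far in a functional assay on B16-F10 cells (Homo sapiens) for cytotoxicity against B16-F10 (Mus musculus), read by MTT assay, with a stated time of 72 h; on this read-out higher numbers stand for an effect only at larger amounts of compound and lower numbers for an effect already at smaller amounts:
Compound 1 `O=C1/C(=C\c2cc3ccccc3nc2Cl)c2ccccc2N1c1c(Cl)cccc1Cl` — "not determined" (no result reported).
Compound 2 `Cc1ccc2nc(Cl)c(/C=C3\C(=O)N(c4c(Cl)cccc4Cl)c4ccccc43)cc2c1C` — > 100 ug/mL, a limit of the assay only.
Compound 3 `CN(C)c1ccc(/C=C2\C(=O)N(c3c(Cl)cccc3Cl)c3ccccc32)cc1` — > 100 ug/mL, likewise a limit only.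

Compound 3 therefore stands at the limit, with no single number of its own. Two of the three entries sit at that same limit (the limit of > 100 ug/mL in this assay, at which 2 of the 3 values shown sit). Among the measured compounds shown here, no step between measured compounds can be drawn from these values. Compound 4 `O=C1/C(=C\c2cccc(Cl)c2)c2ccccc2N1c1c(Cl)cccc1Cl` is not yet measured; it differs from compound 3 by 3-chlorophenyl in place of 4-(dimethylamino)phenyl on a double-bonded chain carbon bound to a double-bonded ring carbon. With nothing but limits to go on, the expected step is a number no higher from compound 3 to compound 4 (the limit leaves the size open), none beyond the scatter. Compound 4 is expected at 100 ug/mL, range 30 ug/mL to 300 ug/mL, most likely again reported only as a limit in this assay.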

Compound 4, concentration for half-maximal effect: 8 ug/mL
Compound 4: middle estimate off by 13-fold (1.10 log units), on the high side, and the stated range ends above it.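

In this assay, the place on a double-bonded chain carbon bound to a double-bonded ring carbon proves responsive: 3-chlorophenyl in place of 4-(dimethylamino)phenyl gives an at least 12-fold lower number from compound 3 to compound 4 (1.09 log units; beyond the scatter). Compound 4 is the only entry shown with a number of its own, so a change at this place alone can bring the read-out off the limit. The true size of the step stays unknown, since the value of compound 3 is only a limit: the limit of > 100 ug/mL in this assay, at which 2 of the 4 values shown sit.

On these data alone, whether the step follows from the chlorine entering or from the dimethylamino group leaving stays open; a plain phenyl at this place would separate the two. Also open, as far as these compounds go, is how a methoxyphenyl or a benzoic acid group would read at this place.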